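A few compounds are considered here, and "the series" means these few. Any claim that something is new, unique, unknown or untested is made for them only; others in the source may bear on it.

In an ADME assay on MT4 cells (Homo sapiens) for cytotoxicity, read by MTT assay, with a stated time of 4 days (on this read-out higher numbers stand for lower toxicity in this test and lower numbers for higher toxicity in this test), compound 1 (`O=C(COc1cccc2ccccc12)N/N=C/c1ccc(Br)cc1`) gives 106 ug/mL and compound 2 (`O=C(COc1cccc2ccccc12)N/N=C/c1ccccc1[N+](=O)[O-]`) gives 12.2 ug/mL on the same read-out. Compound 1 thus holds the higher of the two numbers, with a gap to compound 2 that lies beyond the usual scatter. For the measured compounds named here, no two measured compounds differ in one place only, so no single change has yet been followed through the series. Compound 3 (`O=C(COc1cccc2ccccc12)N/N=C/c1ccc(F)cc1`) still awaits measurement. It departs from compound 1 by one group (fluoro in place of bromo on an aromatic carbon), with fluoro in place of bromo on an aromatic carbon, para to a large group. A modest move toward a lower number is expected, possibly no larger than the scatter, since compound 1 at 106 ug/mL stands at the high end of what is known and compound 2 at 12.2 ug/mL shows that much lower numbers occur. The estimated step is a 1.5-fold lower number from compound 1 to compound 3 (0.18 log units; within the scatter) on this reasoning, and it remains an expectation only. For compound 3 the expected value is 70 ug/mL with an estimated range from 20 ug/mL to 160 ug/mL on this evidence.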

Compound 3, half-maximal cytotoxic concentration: 65.1 ug/mL
Compound 3: the middle estimate sits 1.1-fold (0.03 log units) above what was measured, within the range that was stated.
By their numbers in this assay, from the lowest: compound 2; then compounds 3 and 1 (each within the scatter of the next).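

Working note on the series: in this assay, the change from 4-bromophenyl to 4-fluorophenyl, on an aromatic carbon para to a large group, provides the first single-place comparison, giving a 1.6-fold lower number from compound 1 to compound 3 (0.21 log units; within the scatter) as the step for this exchange. At this position and on this core, fluoro in place of bromo therefore produces no difference that stands clear of the scatter, so this read-out does not separate the two halogens here, a finding that applies to this one pair only. No measurement is available that would explain this result or connect it to any property of either group.

Still open, going by these compounds, is whether a group other than a halogen on the same aromatic carbon, such as an amine, a methoxy group or a carboxylic acid, would give a step beyond the scatter in this assay, and whether chloro would remain within the scatter of bromo and fluoro. Also open, on these data alone, is whether fluoro in place of bromo would give a step of similar size on a different core, as a single pair cannot settle how far this result extends.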